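The compounds below may be only part of what the source reports. "The series", "measured", "known", "first", "only" and "open" are said of these compounds alone.

Measured so far in an assay on HEK293 cells for positive allosteric modulation of metabotropic glutamate receptor 2 (Rattus norvegicus), read by thallium flux; on this read-out higher numbers stand for larger maximal responses and lower numbers for smaller maximal responses:
- compound 1, `O=C(O)c1cc(-c2cccc(COc3ccc4c(c3)CN(CC3CC3)C4=O)c2)ccc1Cl`: 85.7%
- compound 2, `O=C(O)c1cc(-c2cccc(COc3ccc4c(c3)CN(Cc3ccc(C(F)(F)F)cc3)C4=O)c2)ccc1Cl`: 86.7%

Among the compounds with values here, compound 2 and compound 1 give numbers that lie within the scatter of each other; the step of a number 1 percentage points higher from compound 1 to compound 2 (within the scatter) is the only comparison measured, and it shows no real movement. Against this background stands compound 3, `CC(C)N1Cc2cc(OCc3cccc(-c4ccc(Cl)c(C(=O)O)c4)c3)ccc2C1=O`, not yet measured. It differs from compound 2 in one place: isopropyl in place of 4-(trifluoromethyl)benzyl on an amide-type nitrogen in a ring.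

Within the data shown here, the one measured step bears on this change, since it also varies the group on the same amide-type nitrogen of the ring: a number 1 percentage points higher from compound 1 to compound 2 (within the scatter), a change from a small saturated ring to a large aromatic ring without effect beyond scatter. Nothing measured links the size of this substituent to the maximal response. For compound 3 the estimated step is therefore a number 1.7 percentage points lower from compound 2 to compound 3 (within the scatter), within scatter. Compound 3 is expected to give 85%, with a range from 72% to 98%.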

Compound 3, largest response reached (Emax), in percent of the reference or control that the assay uses: 88.1%
Beside the measured number, compound 3's estimate is 3.1 percentage points below it, within the range that was stated.
By their numbers in this assay, from the lowest: compounds 1, 2 and 3 (each within the scatter of the next).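

In this assay, the substituent on the amide-type nitrogen in a ring can now be reduced to isopropyl, which has 3 heavy atoms and no ring, without a shift beyond the scatter from 4-(trifluoromethyl)benzyl, which has 11 heavy atoms (with a number 1.4 percentage points higher from compound 2 to compound 3 (within the scatter)). The comparison with the other small group gives the same picture (with a number 2.4 percentage points higher from compound 1 to compound 3 (within the scatter)), so neither a ring in this substituent nor a cyclopropyl or aromatic ring specifically is needed to hold the maximal response among these three compounds. No supporting measurement is available to explain this flat response.

The compounds shown carry only carbon-based substituents at this nitrogen, some fluorinated, so a primary amine or a carboxylic acid on a longer chain remains untested here. As far as these compounds go, whether the hydrogen-substituted nitrogen holds the response also remains open.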